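Moving the Thiazole Attachment Point Across Two Cores

A few compounds are considered here, and "the series" means these few. Any claim that something is new, unique, unknown or untested is made for them only; others in the source may bear on it.

Compound 1 `Oc1nnc(-c2nccs2)c2ccccc12` and compound 2 `Oc1nnc(-c2cncs2)c2ccccc12` share one core; compound 3 `CCn1nc(-c2nccs2)c2ccccc2c1=O` and compound 4 `CCn1nc(-c2cncs2)c2ccccc2c1=O` share another, and the difference between the two cores is not broken down here. In a functional assay (trachea) with Cavia porcellus as the target (a higher number here means a weaker inhibitor, a lower number a stronger inhibitor), compound 1 gives 4570 nM, while compound 2 gives 1200 nM. The change between them, (1,3-thiazol-5-yl in place of 1,3-thiazol-2-yl on an aromatic carbon), produced a 3.8-fold lower number from compound 1 to compound 2 (0.58 log units; beyond the scatter). In this assay compound 3 gives 3160 nM. Compound 4 carries the same kind of change, (1,3-thiazol-5-yl in place of 1,3-thiazol-2-yl on an aromatic carbon), yet the surroundings differ: in compound 1 the carbon is para to a hydroxy group, whereas in compound 3 it is meta to an ethyl group and para to a group of 1 heavy atom. A drop of similar size is expected for compound 4 because a 3.8-fold lower number from compound 1 to compound 2 (0.58 log units; beyond the scatter) lay beyond the scatter, which means an expected step of a 3.5-fold lower number from compound 3 to compound 4 (0.55 log units; beyond the scatter). Compound 4 is therefore estimated at 900 nM, most likely between 400 nM and 2500 nM.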

Compound 4, half-maximal inhibitory concentration: 562 nM
Compound 4: the middle estimate sits 1.6-fold (0.20 log units) above what was measured, within the range that was stated.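

In this assay the change to 1,3-thiazol-5-yl from 1,3-thiazol-2-yl gave a 5.6-fold lower number from compound 3 to compound 4 (0.75 log units; beyond the scatter) on the second core, the same direction as on the first. The two steps also agree in size: the same change on two cores in this assay, a 3.8-fold lower number (0.58 log units; beyond the scatter) from compound 1 to compound 2 and a 5.6-fold lower number (0.75 log units; beyond the scatter) from compound 3 to compound 4, 1.5-fold (0.17 log units) apart, within the scatter of two such steps. This shows that the change carried over between these two cores, but two pairs cannot show that it would carry to a different core, and these numbers do not explain why the 1,3-thiazol-5-yl compounds give the lower values.

The compounds shown leave open whether a longer chain such as butyl in place of the ethyl group would alter the step. They also leave open whether a pyridine ring in place of the thiazole would give a similarly low number.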